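The compounds below may be only part of what the source reports. "The series", "measured", "known", "first", "only" and "open" are said of these compounds alone.

Measured in a functional assay on HepG2 cells (Homo sapiens) for cytotoxicity, read by MTT assay, with a stated time of 24 h (on this read-out lower numbers stand for stronger inhibition and higher numbers for weaker inhibition), so far:
- compound 1 `COc1cc(/C=C2\CN(C)C/C(=C\c3ccc(Br)cc3)C2=O)cc(OC)c1OC` gives 6800 nM
- compound 2 `COc1cc(/C=C2\CN(C)C/C(=C\c3cccc([N+](=O)[O-])c3)C2=O)cc(OC)c1OC` gives 1890 nM

Of the two, compound 2 has the lower number, and the gap to compound 1 lies beyond the scatter. The next compound, compound 3 `COc1cc(/C=C2\CN(C)C/C(=C\c3ccc(C#N)cc3)C2=O)cc(OC)c1OC`, has not yet been measured in this assay and differs from compound 2 in one place. It has 4-cyanophenyl in place of 3-nitrophenyl on a double-bonded chain carbon bound to a double-bonded ring carbon, a change counted as 4-cyanophenyl in place of 3-nitrophenyl on a double-bonded chain carbon bound to a double-bonded ring carbon in full.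

Among the compounds with values here, only one measured step bears on this place. That is a 3.6-fold lower number from compound 1 to compound 2 (0.56 log units; beyond the scatter), a modest step in which 3-nitrophenyl replaced 4-bromophenyl. Within the data shown here, no measured compound carries 4-cyanophenyl, so this single step is a thin guide. Since the name 4-cyanophenyl shares its number with the 4-bromophenyl of compound 1, a modest move back towards higher numbers is expected, probably not past compound 1. The expected change is a 1.7-fold higher number from compound 2 to compound 3 (0.23 log units; within the scatter) as an estimate. For compound 3 the estimated value is 3200 nM, with an expected range from 1100 nM to 9000 nM as its upper end.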

Compound 3, half-maximal inhibitory concentration: 1140 nM
Beside the measured number, compound 3's estimate is 2.8-fold (0.45 log units) above it, within the range that was stated.
By their numbers in this assay, from the lowest: compounds 3 and 2 (each within the scatter of the next); then compound 1.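

In this assay, 4-cyanophenyl in place of 3-nitrophenyl on a double-bonded chain carbon bound to a double-bonded ring carbon gives a 1.7-fold lower number from compound 2 to compound 3 (0.22 log units; within the scatter), so this read-out does not separate the two groups at this place, even though they differ in their substituent and its ring number. The step with the ring number kept, cyano in place of bromo on an aromatic carbon, gives a 6.0-fold lower number from compound 1 to compound 3 (0.78 log units; beyond the scatter), which shows that the 4-substituted pattern of compound 1 does not by itself carry the higher number and that the identity of the substituent matters. The earlier step could not show this, as it changed the substituent and its ring number together, and nothing available here accounts for either new step.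

The compounds shown leave open how a phenyl without any substituent would compare at this place, and whether a phenyl bearing an amine or a carboxylic acid would stay with compound 2 and compound 3 or move towards compound 1. They also leave open whether the gap between cyano and bromo would persist if the other arm of the shared core were changed.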